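Working notes: from compound 3 to compound 4

The source may hold more compounds than are shown below. What is called first, only, known or untested is meant among the compounds shown, and "the series" means these compounds.

In a functional assay on RS4-11 cells (Homo sapiens) for inhibition, read by CCK-8 assay, with a stated time of 48 h (a lower number here means a stronger inhibitor, a higher number a weaker inhibitor), compound 1 (`COc1ccc(NC(=O)NCCNS(=O)(=O)c2sccc2-c2ccc(C)cc2Oc2ccc(O)c(O)c2)cc1`) gives 8200 nM, compound 2 (`Cc1ccc(-c2ccsc2S(=O)(=O)NCCNC(=O)Nc2ccc([N+](=O)[O-])cc2)c(Oc2ccc(O)c(O)c2)c1`) gives 7700 nM and compound 3 (`Cc1ccc(-c2ccsc2S(=O)(=O)NCCNC(=O)Nc2cc(Cl)cc(Cl)c2)c(Oc2ccc(O)c(O)c2)c1`) gives 5100 nM. Compound 3 therefore stands within the scatter of both other compounds, and the three cannot be ranked on these numbers.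

The next compound is compound 4 (`Cc1ccc(-c2ccsc2S(=O)(=O)NCCNC(=S)Nc2cccc([N+](=O)[O-])c2)c(Oc2ccc(O)c(O)c2)c1`). The change from compound 3 is a group of 12 heavy atoms (7 carbon, 2 nitrogen, 2 oxygen, 1 sulfur; one six-membered aromatic ring of carbon only) in place of a group of 11 heavy atoms (7 carbon, 1 nitrogen, 1 oxygen, 2 chlorine; one six-membered aromatic ring of carbon only), on an amine nitrogen. It sits on an amine nitrogen, and the group that enters carries a nitro group and sulfur.

Among the measured compounds shown here, three measured steps bear on this change. With nitro in place of methoxy, the step is a 1.1-fold lower number from compound 1 to compound 2 (0.03 log units; within the scatter). With 3,5-dichlorophenyl in place of 4-methoxyphenyl, it is a 1.6-fold lower number from compound 1 to compound 3 (0.21 log units; within the scatter). With 3,5-dichlorophenyl in place of 4-nitrophenyl, it is a 1.5-fold lower number from compound 2 to compound 3 (0.18 log units; within the scatter). All three lie within the scatter, so exchanges of this kind have not yet separated the compounds. For the measured compounds named here, none of the measured steps introduces the sulfur of the entering group, so that part of the change is untested and the range must stay wide.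

No direction can be supported, and the expected result is a 1.1-fold higher number from compound 3 to compound 4 (0.03 log units; within the scatter), a step not expected to exceed the scatter. For compound 4 the estimated value is 5500 nM, with an expected range of 2200 nM to 12000 nM.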

Compound 4, half-maximal inhibitory concentration: 6100 nM
Compound 4: the middle estimate sits 1.1-fold (0.04 log units) below what was measured; the measured number falls inside the stated range.
By their numbers in this assay, from the lowest: compounds 3, 4, 2 and 1 (each within the scatter of the next).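

In this assay the group carrying sulfur on the amine nitrogen gives a 1.2-fold higher number from compound 3 to compound 4 (0.08 log units; within the scatter) and a 1.3-fold lower number from compound 2 to compound 4 (0.10 log units; within the scatter) and a 1.3-fold lower number from compound 1 to compound 4 (0.13 log units; within the scatter) with all three steps inside the scatter. Sulfur, absent from the earlier compounds, thus appears at this position without separating compound 4 from any of them, and the four compounds, with their different aromatic groups on this nitrogen, remain unranked. No measurement in hand offers an explanation for this flat result.

Still open is whether this position can separate compounds at all: the groups shown on this nitrogen all carry a six-membered aromatic ring of carbon, and a group of another kind, such as a carboxylic acid, an amine or a longer saturated chain, is not among them. The sulfur also remains unresolved from the other differences in its group, as every step to compound 4 alters more than that one atom.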